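The compounds below may be only part of what the source reports. "The series", "measured", "known", "first", "only" and "open" are said of these compounds alone.

Compound 2 `CCCNCC(=O)Nc1ccc(C2NC(=O)C(C)(C)c3ccccc32)cc1` gives 435 mg/kg in a toxicity assay on the whole organism with Mus musculus as the target, in the rotarod test; a lower number here means that less compound is needed, a higher number that more compound is needed for the effect. It stands alongside compound 1 `CCCNCC(=O)Nc1ccc(C2NC(=O)C(C)c3ccccc32)cc1`, which in this assay gives 340 mg/kg, the step of a 1.3-fold higher number from compound 1 to compound 2 (0.11 log units; within the scatter) lying within the scatter. Compound 3 `CCCCN(CCCC)CC(=O)Nc1ccc(C2NC(=O)C(C)(C)c3ccccc32)cc1` differs from compound 2 by dibutylamino in place of propylamino on a saturated chain carbon bound to a carbonyl carbon. For the measured compounds named here, no measured step bears on this change: the one step recorded concerns a saturated ring carbon, not the chain that carries the amine. The expectation for compound 3 therefore rests on compound 2 alone, and the expected step is a 1.1-fold lower number from compound 2 to compound 3 (0.04 log units; within the scatter), which stays within the scatter. Compound 3 is estimated at 400 mg/kg, with a range from 200 mg/kg to 800 mg/kg.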

Compound 3, dose for half-maximal effect: 600 mg/kg
The estimate for compound 3 lay 1.5-fold (0.18 log units) below the measured number; the measured number falls inside the stated range.
By their numbers in this assay, from the lowest: compounds 1, 2 and 3 (each within the scatter of the next).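

For the compounds shown here, the earlier step concerned only a saturated ring carbon, so this is the first view of the saturated chain carbon bound to a carbonyl carbon. There, dibutylamino in place of propylamino gives a 1.4-fold higher number from compound 2 to compound 3 (0.14 log units; within the scatter) in this assay, although the change adds heavy atoms and removes the hydrogen-bond donor. Nothing measured here offers an explanation for this step. The compounds shown leave open how a piperidine ring or a carboxylic acid would read at this position, and whether dibutylamino would give a similar step on the core of compound 1.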